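A few compounds are considered here, and "the series" means these few. Any claim that something is new, unique, unknown or untested is made for them only; others in the source may bear on it.

Of the compounds shown here, three that share one core have been measured in a functional assay on SK-BR-3 cells (Homo sapiens) for antiproliferative activity; a lower number here means a stronger inhibitor, a higher number a weaker inhibitor. Compound 1 `CC(=O)Oc1ccc(C(=O)Nc2cc3ccc(OCCC4CCCCN4)c(C)c3oc2=O)cc1CC=C(C)C` gives 640 nM. Compound 2 `CCN(CC)CCCOc1ccc2cc(NC(=O)c3ccc(O)c(CC=C(C)C)c3)c(=O)oc2c1C` gives 4900 nM. Compound 3 `CC(C)=CCc1cc(C(=O)Nc2cc3ccc(OCCCNC(C)C)c(C)c3oc2=O)ccc1O` gives 750 nM. On these numbers compound 3 stands second highest of the three: compound 1 lies within the usual scatter of it, while compound 2 stands clearly higher, beyond the scatter.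

Within the data shown here, only one measured pair differs in a single place, and it is a 6.5-fold lower number from compound 2 to compound 3 (0.82 log units; beyond the scatter), where diethylamino was replaced by isopropylamino on a saturated chain carbon, three bonds along the chain from an oxygen on an aromatic ring. Compound 4 `CC(C)=CCc1cc(C(=O)Nc2cc3ccc(OCCCN(C)C4CCCCC4)c(C)c3oc2=O)ccc1O` alters that same place once more: cyclohexyl(methyl)amino in place of isopropylamino on a saturated chain carbon, three bonds along the chain from an oxygen on an aromatic ring.

That one step is all there is to go on. It showed that a tertiary amine with no hydrogen-bond donor, the diethylamino of compound 2, went with a markedly higher number than the isopropylamino of compound 3. Compound 4 returns to a tertiary amine with 0 hydrogen-bond donors, and a bulkier one. The number is therefore expected to move upward, by an estimated 1.9-fold higher number from compound 3 to compound 4 (0.27 log units; within the scatter). Compound 4 is expected to give about 1400 nM, with a likely range from 450 nM to 4500 nM.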

Compound 4, half-maximal inhibitory concentration: 970 nM
For compound 4 the middle estimate is 1.4-fold (0.16 log units) above the measured one, and the stated range covers the measured number.
By their numbers in this assay, from the lowest: compounds 1, 3 and 4 (each within the scatter of the next); then compound 2.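

In this assay, this place on the chain accepts a much larger group with no change beyond the scatter: going from isopropylamino, with 4 heavy atoms and 1 hydrogen-bond donor, to cyclohexyl(methyl)amino, with 8 heavy atoms, a six-membered ring and 0 hydrogen-bond donors, gives a 1.3-fold higher number from compound 3 to compound 4 (0.11 log units; within the scatter) in this series. Neither the donor on this amine nor a small group is therefore required to keep the number in this range. Diethylamino now stands alone, as a 5.1-fold lower number from compound 2 to compound 4 (0.70 log units; beyond the scatter) separates it from another amine without a hydrogen-bond donor, so the missing donor cannot by itself account for the higher number seen with diethylamino.

From the compounds shown here alone, how far this tolerance extends remains open, for instance with a morpholine or a piperazine at the end of the chain, or with a longer chain between the oxygen and the amine. Nothing available here explains why diethylamino sits apart from the other two amines.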